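Aryl Variation and Cytotoxicity in BJ Cells

The compounds below may be only part of what the source reports. "The series", "measured", "known", "first", "only" and "open" are said of these compounds alone.

Compound 1, `CCOC(=O)CCCCCOc1cccc(CN(C(=O)c2ccc(-c3cccc4ccccc34)cc2)C(C)C)c1`, gives in an ADME assay on BJ cells (Homo sapiens) for cytotoxicity, read by CellTiter-Glo and resazurin assay, with a stated time of 72 h (a higher number here means that more compound is needed for the effect, a lower number that less compound is needed), only a limit, > 26000 nM.
Compound 2, `CCOC(=O)CCCCCOc1cccc(CN(C(=O)c2ccc(-c3ccc4ccccc4c3)cc2)C(C)C)c1`, gives in this assay only a limit, > 26000 nM.
Compound 3, `CCOC(=O)CCCCCOc1cccc(CN(C(=O)c2ccc(-c3ccncc3)cc2)C(C)C)c1`, gives in this assay only a limit, > 26000 nM.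

Compound 3 thus stands at the same limit as the two other measured compounds, a point summed up by the limit of > 26000 nM in this assay, at which 3 of the 3 values shown sit. Compound 4, `CCOC(=O)CCCCCOc1cccc(CN(C(=O)c2ccc(-c3cccc(-c4ccccc4)c3)cc2)C(C)C)c1`, differs from compound 3 in one place: 3-phenylphenyl in place of pyridin-4-yl on an aromatic carbon. Going by the values given here, three measured steps touch the same position on the shared core. The step that the two limits leave unreadable from compound 1 to compound 3 and the step that the two limits leave unreadable from compound 2 to compound 3 both replace a carbon-only ring system with pyridin-4-yl, and the step that the two limits leave unreadable from compound 1 to compound 2 moves the attachment point within naphthalene; none of them yields a readable size in this assay, since every value sits at a limit. Among the compounds with values here, no measured step therefore tells how large the change from pyridin-4-yl to 3-phenylphenyl should be, nor in which direction. The plainest expectation is that compound 4 also reaches only the limit, so the step of a number no higher from compound 3 to compound 4 (the limit leaves the size open) is estimated as no reading beyond the scatter. For compound 4 the estimate in this assay is 26000 nM, with a range from 9000 nM to 60000 nM.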

Compound 4, half-maximal effective concentration: > 26000 nM
Compound 4: no number, only a limit; the forecaster's own chance of this, stated with the estimate: 75%; the middle value sits exactly at the limit.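

Compound 4 also gives only a limit, so none of the steps linking compound 1, compound 2, compound 3 and compound 4 can be read in this assay: the limit of > 26000 nM in this assay, at which 4 of the 4 values shown sit.

The compounds shown leave open at what concentration any of them would reach the half-maximal effect, and whether exchanging these ring groups changes that concentration at all.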